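The source may report more compounds than this note shows. Statements on the series, on what has been measured and on what is new or still open speak of the compounds shown alone.

In a functional assay on KOPN-8 cells (Homo sapiens) for antiproliferative activity, with a stated time of 72 h (on this read-out higher numbers stand for an effect only at larger amounts of compound and lower numbers for an effect already at smaller amounts), compound 1 `COc1ccc(-c2cc(=O)c3c(OC)cc(OC)cc3n2C)cc1` gives 30000 nM. Compound 2 `COc1ccc(-c2cc(=O)c3c(OC)cc(OC)cc3n2Cc2ccccc2)cc1` reaches only a limit in this assay, > 17300 nM. The step that the limit leaves unreadable from compound 1 to compound 2 is therefore unreadable because of the limit of > 17300 nM in this assay, at which 1 of the 3 values shown sits. Compound 3 `COc1ccc(-c2cc(=O)c3c(OC)cc(OC)cc3n2S(=O)(=O)c2cccc([N+](=O)[O-])c2)cc1` also reaches only a limit in this assay, > 39600 nM. Among the three values shown, compound 1 alone gives a number, while compound 3 sits at one of the two limits together with the other limited value. Compound 4 `COc1ccc(-c2cc(=O)c3c(OC)cc(OC)cc3n2S(=O)(=O)c2ccc(F)cc2)cc1` differs from compound 3 by 4-fluorophenyl in place of 3-nitrophenyl on a sulfonyl sulfur. No measured step changes a group on the sulfonyl sulfur, so none bears directly on this change, and the single shown step gives no readable size. The step that the limit leaves unreadable from compound 3 to compound 4 is expected to stay within the scatter. Compound 4 is estimated at 40000 nM, with a range from 15000 nM to 100000 nM.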

Compound 4, half-maximal effective concentration: > 65500 nM
Compound 4: a limit, no number (the forecaster's own chance of this, stated with the estimate: 70%); middle value at least 1.6-fold (0.21 log units) from the limit.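

The steps from compound 2 and from compound 3 to compound 4 cannot be read in this assay because compound 4 sits at a limit: the limit of > 65500 nM in this assay, at which 1 of the 4 values shown sits.

Unlike those two compounds' limits, this limit yields a readable step for a sulfonyl group: (4-fluorophenyl)sulfonyl in place of methyl on the aromatic nitrogen gives an at least 2.1-fold higher number from compound 1 to compound 4 (0.33 log units; beyond the scatter). Compound 4 therefore shows its effect only at larger amounts than compound 1 does.

As far as these compounds go, what a longer chain ending in an amine, or a carboxylic acid, would do on that aromatic nitrogen stays open.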